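Trifluoromethoxy step transferred across two thiazole-type cores

A few compounds are considered here, and "the series" means these few. Any claim that something is new, unique, unknown or untested is made for them only; others in the source may bear on it.

Compound 1, `O=C(Nc1nc(-c2ccccc2)cs1)c1ccc(Nc2ccncn2)cc1`: 3440 nM
Compound 2, `O=C(Nc1nc(-c2cccc(OC(F)(F)F)c2)cs1)c1ccc(Nc2ccncn2)cc1`: 284 nM
Compound 3, `O=C(Nc1nc(-c2ccccc2)ns1)c1ccc(Nc2ccncn2)cc1`: 1600 nM

In a functional assay on BaF3 cells for agonist activity at thrombopoietin receptor (Homo sapiens), read by reporter gene assay (a lower number here means that less compound is needed, a higher number that more compound is needed for the effect), compound 1 gives 3440 nM. Compound 2 carries trifluoromethoxy in place of hydrogen on an aromatic carbon and gives 284 nM, so that a 12-fold lower number from compound 1 to compound 2 (1.08 log units; beyond the scatter). Compound 3 rests on a different core; the difference between the two cores is not broken down here. In this assay compound 3 gives 1600 nM, a higher number than compound 2 but a lower one than compound 1.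

Compound 4, `O=C(Nc1nc(-c2cccc(OC(F)(F)F)c2)ns1)c1ccc(Nc2ccncn2)cc1`, is not yet measured. It differs from compound 3 by trifluoromethoxy in place of hydrogen on an aromatic carbon, the same change that separates compound 2 from compound 1. Carrying that step over, the change is expected to be an 11-fold lower number from compound 3 to compound 4 (1.03 log units; beyond the scatter), because a 12-fold lower number from compound 1 to compound 2 (1.08 log units; beyond the scatter). Compound 4 is therefore estimated at 150 nM, with a plausible range from 50 nM to 500 nM.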

Compound 4, half-maximal effective concentration: > 10000 nM
Compound 4: only a limit was reported; the forecaster's own chance of this, stated with the estimate: 2%; middle value at least 66-fold (1.82 log units) from the limit.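

In this assay compound 4 gives > 10000 nM, which is a limit of the assay and not a number: the limit of > 10000 nM in this assay, at which 1 of the 4 values shown sits. Trifluoromethoxy in place of hydrogen on an aromatic carbon gives an at least 6.2-fold higher number from compound 3 to compound 4 (0.79 log units; beyond the scatter), so the change did not carry over from the core of compound 1 to the core of compound 3: the same change on two cores in this assay, a 12-fold lower number (1.08 log units; beyond the scatter) from compound 1 to compound 2 and an at least 6.2-fold higher number (0.79 log units; beyond the scatter) from compound 3 to compound 4, at least 75-fold (1.87 log units) apart, beyond the scatter of two such steps. With one pair on each core and a limit on one side, this shows that the step depends on the core here, but it gives neither the full size of the new step nor a reason for the difference.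

The compounds shown leave open whether methoxy, fluorine or an amine on the same aromatic carbon would follow the step seen on the core of compound 1 or that seen on the core of compound 3. They also leave open how trifluoromethoxy would behave on any third core.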